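A few compounds are considered here, and "the series" means these few. Any claim that something is new, unique, unknown or untested is made for them only; others in the source may bear on it.

Compound 1 `CCCCNc1nc(N)nc2c1CNCC2`: 7.2 uM
Compound 2 `CCCCNc1nc(N)nc2c1CN(Cc1ccccc1Cl)CC2`: 0.05 uM
Compound 3 `CCCCNc1nc(N)nc2c1CN(Cc1ccncc1)CC2`: 0.29 uM

All three numbers come from an assay on HEK293 cells for agonist activity at Toll-like receptor 8 (Homo sapiens), read by a luciferase reporter, with a stated time of 6 h; on this read-out higher numbers stand for an effect only at larger amounts of compound and lower numbers for an effect already at smaller amounts. Among them compound 3 holds the second highest number; the nearest neighbour is set by a 5.8-fold higher number from compound 2 to compound 3 (0.76 log units; beyond the scatter), the furthest by a 25-fold lower number from compound 1 to compound 3 (1.39 log units; beyond the scatter). Compound 4 `CCCCNc1nc(N)nc2c1CN(Cc1ccco1)CC2` differs from compound 3 in one place: furan-2-yl in place of pyridin-4-yl on a saturated chain carbon bound to an amine nitrogen in a ring. Going by the values given here, the steps that bear on this are those at the same amine nitrogen in a ring. Placing a group there gave a 140-fold lower number from compound 1 to compound 2 (2.16 log units; beyond the scatter) and a 25-fold lower number from compound 1 to compound 3 (1.39 log units; beyond the scatter), both large, whereas exchanging one aromatic group for another gave a 5.8-fold higher number from compound 2 to compound 3 (0.76 log units; beyond the scatter), only modest. A further exchange of one aromatic ring for another is therefore expected to give a modest step, direction uncertain, a 1.4-fold higher number from compound 3 to compound 4 (0.14 log units; within the scatter). Compound 4 is estimated at 0.4 uM, within 0.1 uM to 1.5 uM.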

Compound 4, minimum effective concentration: 0.08 uM
Estimate against measurement, compound 4: 5.0-fold (0.70 log units) above, and the stated range ends above it.
By their numbers in this assay, from the lowest: compounds 2 and 4 (each within the scatter of the next); then compound 3; then compound 1.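

In this assay, the choice of aromatic ring at this position can matter: furan-2-yl in place of pyridin-4-yl gave a 3.6-fold lower number from compound 3 to compound 4 (0.56 log units; beyond the scatter) on this read-out. Furan-2-yl in place of 2-chlorophenyl gave a 1.6-fold higher number from compound 2 to compound 4 (0.20 log units; within the scatter), so here a five-membered ring does as well as a chlorinated six-membered one, and (furan-2-yl)methyl in place of hydrogen gave a 90-fold lower number from compound 1 to compound 4 (1.95 log units; beyond the scatter) as a third large step at this amine nitrogen. No available measurement explains these differences. Still open, going by these compounds, is how a thiophen-2-yl or cyclohexyl group would compare on the same saturated chain carbon.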